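The source may report more compounds than this note shows. Statements on the series, on what has been measured and on what is new or still open speak of the compounds shown alone.

Values measured in a functional assay on SK-N-SH cells (Homo sapiens) for cytotoxicity, read by MTT assay, with a stated time of 48 h; on this read-out lower numbers stand for stronger inhibition and higher numbers for weaker inhibition:
- compound 1 `COc1ccc(/C=C/c2cc(OC)c(OC)c(OC)c2-c2ccc(OC)cc2)cc1`: 36000 nM
- compound 2 `COc1ccc(/C=C/c2cc(OC)c(OC)c(OC)c2-c2ccc(F)c(C)c2)cc1`: 19000 nM
- compound 3 `C=C(c1ccc(OC)cc1)c1cc(OC)c(OC)c(OC)c1-c1ccc(OC)cc1`: 75000 nM

Compound 3 has the highest number of the three in this assay, at 75000 nM. The measured step to it is a 2.1-fold higher number from compound 1 to compound 3 (0.32 log units; beyond the scatter), but this change lies elsewhere in the structure and gives no guide to the next one.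

Compound 4 `C=C(c1ccc(OC)cc1)c1cc(OC)c(OC)c(OC)c1-c1ccc(Cl)cc1` follows from compound 3 with chloro in place of methoxy on an aromatic carbon, that is, 4-methoxyphenyl to 4-chlorophenyl. Among the measured compounds shown here, no chloro compound has been measured. For the measured compounds named here, the nearest precedent is 4-fluoro-3-methylphenyl in place of 4-methoxyphenyl, seen as a 1.9-fold lower number from compound 1 to compound 2 (0.28 log units; within the scatter). That step stays within the scatter and was measured with the 2-(4-methoxyphenyl)ethenyl group rather than the 1-(4-methoxyphenyl)ethenyl group, so it is only weak support for a slightly lower number.

The expected change is small, a 1.5-fold lower number from compound 3 to compound 4 (0.18 log units; within the scatter).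

For compound 4 the estimated value is 50000 nM, with an expected range of 22000 nM to 100000 nM.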

Compound 4, half-maximal inhibitory concentration: 15000 nM
Estimate against measurement, compound 4: 3.3-fold (0.52 log units) above, outside the stated range (below it).
By their numbers in this assay, from the lowest: compounds 4, 2 and 1 (each within the scatter of the next, the first and the last beyond it); then compound 3.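

Replacing methoxy with chloro on the 4-methoxyphenyl ring gives a 5.0-fold lower number from compound 3 to compound 4 (0.70 log units; beyond the scatter) in this assay, so the number does respond to a change at this place, para to a large group, in the 1-(4-methoxyphenyl)ethenyl compounds. Among the compounds shown here, the only earlier change on this ring, a 1.9-fold lower number from compound 1 to compound 2 (0.28 log units; within the scatter), involved a different group on the 2-(4-methoxyphenyl)ethenyl compounds and stayed within the scatter. No measured evidence here accounts for the step.

Still open, going by these compounds, is whether the same chloro change carries over to the 2-(4-methoxyphenyl)ethenyl compound 1. Also open, on these data alone, is whether other groups at this place, such as an amine, a nitrile or a longer ethoxy chain, shift the number as far as chloro does in compound 4.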